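The source may hold more compounds than are shown below. What is called first, only, known or untested is meant among the compounds shown, and "the series" means these compounds.

Measured in a functional assay on NB-4 cells (Homo sapiens) for cytotoxicity, read by CCK-8 assay, with a stated time of 24 h; a lower number here means a stronger inhibitor, a higher number a weaker inhibitor:
- compound 1 `C=CC(=O)N1C(=O)CC(c2ccc(Br)cc2)Sc2ccccc21`: 59400 nM
- compound 2 `C=CC(=O)N1C(=O)CC(c2cccs2)Sc2ccccc21`: 765000 nM
- compound 3 `C=CC(=O)N1C(=O)CC(c2cccc(Cl)c2)Sc2ccccc21`: 31700 nM

Compound 1 belongs to the close pair at the low end of these numbers. The pair is shown by a 1.9-fold lower number from compound 1 to compound 3 (0.27 log units; within the scatter). The distant member is shown by a 13-fold higher number from compound 1 to compound 2 (1.11 log units; beyond the scatter) and by a 24-fold lower number from compound 2 to compound 3 (1.38 log units; beyond the scatter).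

The next compound is compound 4 `C=CC(=O)N1C(=O)CC(c2ccc(-c3ccccc3)cc2)Sc2ccccc21`, with phenyl in place of bromo on an aromatic carbon, para to a large group: phenyl in place of bromo on an aromatic carbon. Within the data shown here, no measured step makes this change, so the evidence is indirect. All three steps replace the whole group on a saturated ring carbon. The swap to 3-chlorophenyl stayed within the scatter, as a 1.9-fold lower number from compound 1 to compound 3 (0.27 log units; within the scatter) shows. The swap to thiophen-2-yl, a 13-fold higher number from compound 1 to compound 2 (1.11 log units; beyond the scatter), shows that this group can move the number a long way, but it removes the benzene ring that compound 4 keeps.

Going by these compounds, no step beyond the scatter is therefore expected in this assay, and its direction remains open. The expected step is a 1.3-fold lower number from compound 1 to compound 4 (0.12 log units; within the scatter). Compound 4 is estimated at 45000 nM, with an expected range of 15000 nM to 130000 nM.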

Compound 4, half-maximal inhibitory concentration: 57700 nM
Estimate against measurement, compound 4: 1.3-fold (0.11 log units) below; measured number inside the range.
By their numbers in this assay, from the lowest: compounds 3, 4 and 1 (each within the scatter of the next); then compound 2.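

In this assay phenyl in place of bromo on an aromatic carbon, para to a large group, gives a 1.0-fold lower number from compound 1 to compound 4 (0.01 log units; within the scatter) and so leaves the number within the scatter. Among these compounds, this is the first step that keeps the benzene ring and alters only its substituent, and it adds a six-membered aromatic ring of carbon only where bromo carries no ring, without a change beyond the scatter. Nothing on hand accounts for this outcome.

Bromo and phenyl both carry no hydrogen-bond donors, no hydrogen-bond acceptors and no net charge, so whether an amine or a carboxylic acid on this aromatic carbon would also hold the number stays open. Also open, going by these compounds, is whether a longer chain here would behave as phenyl does.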